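The source may report more compounds than this note shows. Statements on the series, on what has been measured and on what is new or still open speak of the compounds shown alone.

Working notes on the series

Compound 1 `COc1ccc([C@@H]2c3c(OC)cc(OC)cc3/C(=C/c3ccc(C)cc3)[C@H]2c2cc(OC)cc(OC)c2)cc1` and compound 2 `COc1ccc([C@@H]2c3c(OC)cc(OC)cc3/C(=C/c3ccc(F)cc3)[C@H]2c2cc(OC)cc(OC)c2)cc1` share one core; compound 3 `COc1ccc([C@@H]2c3c(OC)cc(OC)cc3C(C(O)c3ccc(C)cc3)[C@H]2c2cc(OC)cc(OC)c2)cc1` and compound 4 `COc1ccc([C@@H]2c3c(OC)cc(OC)cc3C(C(O)c3ccc(F)cc3)[C@H]2c2cc(OC)cc(OC)c2)cc1` share another. The difference between the two cores is not broken down here.

In a functional assay on RAW264.7 cells (Mus musculus) for inhibition, with stated times of 2 h and 24 h (on this read-out lower numbers stand for stronger inhibition and higher numbers for weaker inhibition), compound 1 gives > 200000 nM, which is a limit of the assay and not a number. In this assay compound 2 likewise gives > 200000 nM, again a limit. The change from compound 1 to compound 2 is fluoro in place of methyl on an aromatic carbon, and the step it made, a step that the two limits leave unreadable from compound 1 to compound 2, cannot be read because the limit of > 200000 nM in this assay, at which 2 of the 3 values shown sit, sits at both ends. In this assay, among the measured compounds shown here, compound 3 gives 26500 nM, the only number among the three values so far.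

For the measured compounds named here, the change from compound 3 to compound 4 is fluoro in place of methyl on an aromatic carbon: the same change as the one from compound 1 to compound 2. That earlier step gives no readable size, so nothing measured here points to a direction for the new step. For compound 4 the step of a 1.1-fold higher number from compound 3 to compound 4 (0.05 log units; within the scatter) is expected to stay within the usual scatter. Compound 4 is therefore estimated at 30000 nM, with a range from 10000 nM to 100000 nM.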

Compound 4, half-maximal inhibitory concentration: > 200000 nM
Compound 4 was reported as a limit (the forecaster's own chance of this, stated with the estimate: 15%); middle value at least 6.6-fold (0.82 log units) from the limit.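

In this assay fluoro in place of methyl on an aromatic carbon of the core of compound 3 makes an at least 7.5-fold higher number from compound 3 to compound 4 (0.87 log units; beyond the scatter) and so takes this core from a number to a limit. Compound 4 gives > 200000 nM as a limit of the assay and not a number, so the step has a floor but no full size: the limit of > 200000 nM in this assay, at which 3 of the 4 values shown sit. The same change on the core of compound 1 cannot be read, with compound 1 and compound 2 both at a limit, so this shows a loss on one core and neither confirms nor refutes that the change carries over from one core to the other.

Still open, as far as these compounds go, is whether an amine, a carboxylic acid or a chloro group on the same aromatic carbon would keep a number on the core of compound 3. Also open, from the compounds shown here alone, is whether any group there would bring the core of compound 1 to a readable value, which a real comparison of the two cores would need.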